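This account rests on a few compounds, and the source may have more. Where it says the series, first, only, none or still open, it means among the compounds named here.

Measured compounds:
Compound 1, `O=c1c(C2N=C(c3ccccc3)SS2)coc2cc(Cl)ccc12`, in a functional assay on A549 cells (Homo sapiens) for inhibition, read by sulforhodamine B assay, with a stated time of 48 h (on this read-out lower numbers stand for stronger inhibition and higher numbers for weaker inhibition), gives 57500 nM.
Compound 2, `O=c1c(C2N=C(c3ccccc3)SS2)coc2ccc(F)cc12`, in this assay gives 91100 nM.

Both compounds share one core and differ only in the halogen set on the fused ring of that core. Compound 2 stands with the higher of the two numbers, but its nearest neighbour, compound 1, lies within the usual scatter of it, so the two values show no difference that can be trusted. For the measured compounds named here, no step between measured compounds can be computed from this pair.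

Compound 3, `O=c1c(C2N=C(c3ccccc3)SS2)coc2cc(Cl)c(F)cc12`, has not yet been measured in this assay. It differs from compound 2 by a single change: chloro in place of hydrogen on an aromatic carbon. Compound 3 therefore carries both the chloro group seen in compound 1 and the fluoro group seen in compound 2.

Because compound 1 gives 57500 nM and compound 2 gives 91100 nM, both within scatter of each other, the expected step of a 1.8-fold lower number from compound 2 to compound 3 (0.26 log units; within the scatter) is small and not beyond the scatter. Compound 3 is estimated at 50000 nM, with a range from 20000 nM to 120000 nM.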

Compound 3, half-maximal inhibitory concentration: 93500 nM
Estimate against measurement, compound 3: 1.9-fold (0.27 log units) below; measured number inside the range.
By their numbers in this assay, from the lowest: compounds 1, 2 and 3 (each within the scatter of the next).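

For the compounds shown here, compound 3 lets each halogen be read alone for the first time, since compounds 1 and 2 differ in two places and could not be compared directly. In this assay chloro in place of hydrogen on this aromatic carbon, ortho to a fluoro group, gives a 1.0-fold higher number from compound 2 to compound 3 (0.01 log units; within the scatter) and fluoro in place of hydrogen gives a 1.6-fold higher number from compound 1 to compound 3 (0.21 log units; within the scatter), so both steps stay within the scatter and neither single halogen shifts the number in a way that can be trusted, even with the two groups present together on the same ring. Nothing shown here bears on why these numbers stay together.

Going by these compounds, whether a group other than a halogen on this aromatic carbon, such as an amine, a carboxylic acid or a methoxy group, would give a step beyond the scatter remains open. The compounds shown also leave open whether a change elsewhere on the shared core, or an unsubstituted fused ring with neither chloro nor fluoro, would read differently in this assay.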